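The source may hold more compounds than are shown below. What is called first, only, known or untested is meant among the compounds shown, and "the series" means these compounds.

Measured so far:
- compound 1, `O=C(O)C1(Sc2ncnc3ccccc23)CCC1`: in an assay on HEK293 cells for inhibition of solute carrier family 22 member 12 (Homo sapiens), read by scintillation counting, with a stated time of 12 min (on this read-out higher numbers stand for weaker inhibition and lower numbers for stronger inhibition), compound 1 gives only a limit, > 10000 nM.
- compound 2, `O=C(O)C1(Sc2nccc3ncccc23)CCC1`: in this assay compound 2 likewise gives only a limit, > 10000 nM.
- compound 3, `Nc1ccc2nccc(SC3(C(=O)O)CCC3)c2c1`: in this assay compound 3 gives 1790 nM.

For the measured compounds named here, compound 3 thus stands as the only member of the set with a measured number; the other two sit at the limit of > 10000 nM in this assay, at which 2 of the 3 values shown sit. Compound 4, `COCCOc1ccc2nccc(SC3(C(=O)O)CCC3)c2c1`, has not been measured yet. It differs from compound 3 in one place: 2-methoxyethoxy in place of amino on an aromatic carbon. With no measured step of this kind in the set, the expected change from compound 3 to compound 4 is a 1.6-fold higher number from compound 3 to compound 4 (0.19 log units; within the scatter), a modest shift toward weaker inhibition that may not exceed the usual scatter. For compound 4 the estimated value is 2800 nM, with an expected range from 800 nM to 9000 nM.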

Compound 4, half-maximal inhibitory concentration: 207 nM
Beside the measured number, compound 4's estimate is 14-fold (1.13 log units) above it; the whole stated range lies above it.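

In this assay, 2-methoxyethoxy in place of amino on this aromatic carbon gives an 8.6-fold lower number from compound 3 to compound 4 (0.94 log units; beyond the scatter), so the position accepts a larger chain and inhibition does not depend on the amino group. The change replaces a group with a hydrogen-bond donor by one with none, and inhibition still strengthens. No measured property in the set accounts for this step.

From the compounds shown here alone, how much of the chain matters remains open: a plain methoxy, a hydroxyethoxy or a longer chain at this carbon would separate the ether oxygens from chain length.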